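A few compounds are considered here, and "the series" means these few. Any claim that something is new, unique, unknown or untested is made for them only; others in the source may bear on it.

Measured compounds and values:
- compound 1, `O=S(=O)(NCCCNCc1ccccc1Cl)c1cc(C(F)(F)F)cc(C(F)(F)F)c1`: 8800 nM
- compound 2, `O=S(=O)(NCCCNCc1ccc(Cl)c(Cl)c1)c1cc(C(F)(F)F)cc(C(F)(F)F)c1`: 2400 nM
- compound 3, `COc1ccc(CNCCCNS(=O)(=O)c2cc(C(F)(F)F)cc(C(F)(F)F)c2)cc1OC`: 1900 nM

All three share the bis(trifluoromethyl)phenylsulfonamide core and differ only in the aryl group on the saturated chain carbon bound to the amine nitrogen. In a functional assay on MCF7 cells (Homo sapiens) for inhibition, read by MTT assay, with a stated time of 72 h (on this read-out lower numbers stand for stronger inhibition of growth and higher numbers for weaker inhibition of growth), compound 3 gives the lowest number of the three, but its nearest neighbour is compound 2, and a 1.3-fold lower number from compound 2 to compound 3 (0.10 log units; within the scatter), so the two cannot be ordered. Against compound 1 the separation is clear: a 4.6-fold lower number from compound 1 to compound 3 (0.67 log units; beyond the scatter) and a 3.7-fold lower number from compound 1 to compound 2 (0.56 log units; beyond the scatter).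

The next compound is compound 4, `O=S(=O)(NCCCNCc1ccc(Cl)c(C(F)(F)F)c1)c1cc(C(F)(F)F)cc(C(F)(F)F)c1`. Its change from compound 3 is 4-chloro-3-(trifluoromethyl)phenyl in place of 3,4-dimethoxyphenyl on a saturated chain carbon bound to an amine nitrogen. The step that bears most directly on it is the exchange of one 3,4-disubstituted aryl for another, where a 1.3-fold lower number from compound 2 to compound 3 (0.10 log units; within the scatter); compound 4 keeps that 3,4-disubstitution pattern and carries a chlorine as compound 2 does. The two steps from compound 1 are the only ones beyond the scatter and concern the move away from 2-chlorophenyl, which compound 4 does not revisit. No step beyond the scatter is therefore expected in this assay.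

Compound 4 is estimated at 2200 nM, range 900 nM to 5500 nM, the expected step being a 1.2-fold higher number from compound 3 to compound 4 (0.06 log units; within the scatter).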

Compound 4, concentration for 50% growth inhibition: 3500 nM
Compound 4: the middle estimate sits 1.6-fold (0.20 log units) below what was measured; the range from low to high includes it.
By their numbers in this assay, from the lowest: compounds 3, 2 and 4 (each within the scatter of the next); then compound 1.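

At this position, 4-chloro-3-(trifluoromethyl)phenyl reads the same within the scatter in this assay as 3,4-dimethoxyphenyl (a 1.8-fold higher number from compound 3 to compound 4 (0.27 log units; within the scatter)), although the group that leaves carries 2 hydrogen-bond acceptors and the group that enters carries 0, and trifluoromethyl in place of chloro on an aromatic carbon also leaves compounds 2 and 4 unresolved (a 1.5-fold higher number from compound 2 to compound 4 (0.16 log units; within the scatter)). The separation from the 2-chlorophenyl group holds for a third aryl group (a 2.5-fold lower number from compound 1 to compound 4 (0.40 log units; beyond the scatter)), so 3,4-dichlorophenyl, 3,4-dimethoxyphenyl and 4-chloro-3-(trifluoromethyl)phenyl all give lower numbers than compound 1, and no listed compound goes against this. No measurement is available that explains these numbers.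

The compounds shown do not separate the place of a substituent on the aryl group from the number of substituents, since 2-chlorophenyl is the only group of its kind here. From the compounds shown here alone, how a carboxylic acid or an amine on the aryl group, or a longer chain in the shared core, would read in this assay remains open.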